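This account rests on a few compounds, and the source may have more. Where it says the series, first, only, none or still open, it means among the compounds named here.

Measured so far:
- compound 1 `CN(C)c1ccc(C(=O)N2CCC(NS(=O)(=O)c3cc(S(=O)(=O)c4ccccc4)ccc3C(F)(F)F)CC2)cc1`: 300 nM
- compound 2 `CN(C)c1ccc(C(=O)N2CCC(NS(=O)(=O)c3cc(S(=O)(=O)c4ccccc4)ccc3C(F)(F)F)CC2)cn1`: 40 nM
- compound 3 `CC(C)(C)OC(=O)N1CCC(C(=O)N2CCC(NS(=O)(=O)c3cc(S(=O)(=O)c4ccccc4)ccc3C(F)(F)F)CC2)CC1`: 300 nM

All three were tested in an assay on isolated protein for displacement of a labelled ligand from secreted frizzled-related protein 1 (Homo sapiens), read by fluorescence polarization, with a stated time of 30 min; a higher number here means a weaker inhibitor, a lower number a stronger inhibitor. Compound 2 has the lowest number of the three, with compound 1 and compound 3 each sitting higher by the same margin, and both of those gaps are beyond the usual scatter.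

Within the data shown here, the one step within this set that changes a single place is a 7.5-fold lower number from compound 1 to compound 2 (0.88 log units; beyond the scatter), where a nitrogen enters the aromatic ring that hangs on the carbonyl carbon. Compound 4 `O=C(CC1CCNCC1)N1CCC(NS(=O)(=O)c2cc(S(=O)(=O)c3ccccc3)ccc2C(F)(F)F)CC1` changes that same place once more: (piperidin-4-yl)methyl in place of 6-(dimethylamino)pyridin-3-yl on a carbonyl carbon

Among the measured compounds shown here, no measured step covers a swap from an aromatic ring to a saturated ring at this point, so the direction for compound 4 is uncertain. For the measured compounds named here, the only hint is compound 3, whose saturated ring on the carbonyl carbon gives 300 nM, on a par with compound 1 rather than compound 2. On that basis the expectation for compound 4 is a move back up, with a 5.5-fold higher number from compound 2 to compound 4 (0.74 log units; beyond the scatter) as the estimated step. Compound 4 is therefore expected to give about 220 nM, likely between 60 nM and 900 nM.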

Compound 4, half-maximal inhibitory concentration in the secreted frizzled-related protein 1 assay: 100 nM
For compound 4 the middle estimate is 2.2-fold (0.34 log units) above the measured one; the measured number falls inside the stated range.
By their numbers in the secreted frizzled-related protein 1 assay, from the lowest: compound 2; then compound 4; then compounds 1 and 3 (each within the scatter of the next).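

In the secreted frizzled-related protein 1 assay, an aromatic ring on this carbonyl carbon turns out not to be required: (piperidin-4-yl)methyl gives up some ground to 6-(dimethylamino)pyridin-3-yl, with a 2.5-fold higher number from compound 2 to compound 4 (0.40 log units; beyond the scatter), yet it still does better than 4-(dimethylamino)phenyl, with a 3.0-fold lower number from compound 1 to compound 4 (0.48 log units; beyond the scatter). In a physicochemical assay for solubility, at pH 7.4 (a lower number here means a less soluble compound, a higher number a more soluble compound), compound 2 gives 6700 nM. In the physicochemical assay compound 4 gives > 100000 nM, which is a limit of the assay and not a number. The swap that costs a modest step in the secreted frizzled-related protein 1 assay therefore comes with a large gain in the physicochemical assay, and this second measurement adds a dimension that the earlier binding numbers alone could not show: the measured solubility of compound 2, 6700 nM, and of compound 4, > 100000 nM, an at least 14-fold higher number (1.17 log units; beyond the scatter)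

The compounds shown leave open whether the ring or the methyl link in (piperidin-4-yl)methyl carries these steps. A piperidin-4-yl group set directly on the carbonyl carbon, or a morpholine ring joined through the same methyl link, would help to separate those two parts.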